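Changing the anilide ring: expected cytotoxicity of compound 3

The compounds below may be only part of what the source reports. "The series", "measured", "known", "first", "only" and "open" are said of these compounds alone.

Measured so far in an ADME assay on L02 cells (Homo sapiens) for cytotoxicity, read by MTT assay, with a stated time of 72 h; on this read-out higher numbers stand for weaker inhibition and lower numbers for stronger inhibition:
- compound 1 `O=C(CCC(=O)OCCCCCCSc1ccc([N+](=O)[O-])c2nonc12)Nc1ccccc1` gives 6490 nM
- compound 2 `O=C(CCC(=O)OCCCCCCSc1ccc([N+](=O)[O-])c2nonc12)Nc1ccc(C(F)(F)F)cc1` gives 5010 nM

Among the measured compounds shown here, compound 2 holds one of two numbers in this assay, and the only measured step, a 1.3-fold lower number from compound 1 to compound 2 (0.11 log units; within the scatter), is too small to tell the pair apart. Both compounds share the same long chain ending in a nitro-bearing core and differ only in what sits on the phenyl ring attached to the amide nitrogen.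

Compound 3 `COc1ccc(NC(=O)CCC(=O)OCCCCCCSc2ccc([N+](=O)[O-])c3nonc23)cc1OC` is the next member of the set. It differs from compound 2 by 3,4-dimethoxyphenyl in place of 4-(trifluoromethyl)phenyl on an amide-type nitrogen. For the measured compounds named here, the one step available for guidance touched exactly this ring, exchanging hydrogen for trifluoromethyl, and it stayed within the scatter. A second exchange on the same ring therefore gives no ground for expecting a move in either direction in this assay, and the expected step from compound 2 to compound 3 is a 1.2-fold higher number from compound 2 to compound 3 (0.06 log units; within the scatter). For compound 3 the estimated value in this assay is 5800 nM, with a range from 2500 nM to 14000 nM that allows for the usual spread of repeated measurements.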

Compound 3, half-maximal inhibitory concentration: 4100 nM
Beside the measured number, compound 3's estimate is 1.4-fold (0.15 log units) above it; measured number inside the range.
By their numbers in this assay, from the lowest: compounds 3, 2 and 1 (each within the scatter of the next).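

In this assay, a third version of the ring on the amide-type nitrogen leaves the picture flat: there is a 1.2-fold lower number from compound 2 to compound 3 (0.09 log units; within the scatter) and also a 1.6-fold lower number from compound 1 to compound 3 (0.20 log units; within the scatter) against the unsubstituted ring. Among the compounds shown here, earlier, the only exchange on this ring was trifluoromethyl for hydrogen, whereas 3,4-dimethoxyphenyl brings two oxygen atoms and two hydrogen-bond acceptors to a place where phenyl and 4-(trifluoromethyl)phenyl have none, and still compound 1, compound 2 and compound 3 cannot be told apart by this read-out. Nothing measured alongside these numbers offers an explanation for this flat result.

All three rings shown are uncharged phenyl rings, so it remains open whether a ring carrying an amine or a carboxylic acid would also stay within the scatter in this assay or would finally separate from the others. Also open, from the compounds shown here alone, is whether a longer chain, rather than another exchange on the ring, would shift the number by more than repeated measurements normally vary.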